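This account rests on a few compounds, and the source may have more. Where it says the series, first, only, none or still open, it means among the compounds named here.

The series gathers four compounds on a shared core. Compound 1 `CCOc1ccc(-n2c(S)nnc2CSc2nnc(-c3ccccc3)n2-c2ccccc2)cc1` and compound 2 `CC(C)n1c(S)nnc1CSc1nnc(-c2ccccc2)n1-c1ccccc1` carry an ethoxyphenyl group and an isopropyl group on the outer ring of that core, yet for neither of them is a result reported in a functional assay on HT-29 cells (Homo sapiens) for inhibition, read by MTT assay, with a stated time of 48 h; on this read-out lower numbers stand for stronger inhibition and higher numbers for weaker inhibition: in this assay compound 1 gives "not determined" (no result reported) and compound 2 gives "not determined" (no result reported). Compound 3 `Sc1nnc(CSc2nnc(-c3ccccc3)n2-c2ccccc2)n1-c1ccc(Cl)cc1`, with a 4-chlorophenyl group in the same place, is therefore the only compound with a number: in this assay compound 3 gives 36600 nM, a weak inhibition, and it stands alone among the entries shown, so no comparison between measured compounds can be drawn.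

Compound 4 `Sc1nnc(CSc2nnc(-c3ccccc3)n2-c2ccccc2)n1-c1ccccc1` differs from compound 3 in one spot: hydrogen in place of chloro on an aromatic carbon, so the 4-chlorophenyl becomes a plain phenyl. Among the measured compounds shown here, no measured pair in the set shows what such a change does here. For the measured compounds named here, since the single known value for compound 3 is already weak, the step in this assay is expected to be small, with no direction beyond the usual scatter, perhaps leaning toward slightly weaker inhibition as a 1.2-fold higher number from compound 3 to compound 4 (0.09 log units; within the scatter). Compound 4 is therefore estimated at 45000 nM in this assay, with a range from 18000 nM to 110000 nM, and with a fair chance that only a limit rather than a number is reported.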

Compound 4, half-maximal inhibitory concentration: 5490 nM
Beside the measured number, compound 4's estimate is 8.2-fold (0.91 log units) above it; the measured number lies below the stated range.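

Taking the chloro off the 4-chlorophenyl group gives the first readable step at this position in this assay: a 6.7-fold lower number from compound 3 to compound 4 (0.82 log units; beyond the scatter), a change beyond the usual scatter that points to stronger inhibition with the plain phenyl. Among the compounds shown here, the earlier compounds could show only one weak value, whereas this pair shows that the group on the outer ring of the shared core does affect the read-out, even when the change is a single chlorine atom giving way to hydrogen, with no ring, hydrogen-bond donor, hydrogen-bond acceptor or net charge involved. No measurement at hand bears on why the number falls with this change, and the finding rests on this one pair.

The steps to compound 1 and compound 2 cannot be read, so the ethoxyphenyl and isopropyl groups cannot be placed against the plain phenyl of compound 4. Going by these compounds, it also remains open whether the trend away from chloro would hold for a fluoro group, an amine or a carboxylic acid on the same aromatic carbon, or whether a longer chain there would change the number in either direction.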